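A few compounds are considered here, and "the series" means these few. Any claim that something is new, unique, unknown or untested is made for them only; others in the source may bear on it.

Compound 1 `COc1cc(-c2nnc(SCc3ccccc3Br)o2)ccc1O` and compound 2 `COc1cc(-c2nnc(SCc3ccccc3Cl)o2)ccc1O` share one core and differ only in a halogen on an aromatic carbon. In an ADME assay on cells (Mus musculus, strain BALB/c) for cytotoxicity, read by MTT assay, with a stated time of 24 h (on this read-out higher numbers stand for lower toxicity in this test and lower numbers for higher toxicity in this test), compound 1 gives 363000 nM, and compound 2 gives 564000 nM; the step of a 1.6-fold higher number from compound 1 to compound 2 (0.19 log units; within the scatter). Compound 1 thus carries the lower of the two numbers shown, although the gap to compound 2 is within the scatter. Compound 3 `COc1cc(-c2nnc(SCc3ccccc3Br)o2)ccc1OCc1ccccc1Br` arises from compound 1 by 2-bromobenzyl in place of hydrogen on an oxygen on an aromatic ring. Among the measured compounds shown here, no measured step covers a change of this kind, so the single halogen swap offers no guide to its size. The estimate for compound 3 is 200000 nM, between 50000 nM and 600000 nM, so the step of a 1.8-fold lower number from compound 1 to compound 3 (0.26 log units; within the scatter) is expected to be modest.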

Compound 3, half-maximal cytotoxic concentration: 151000 nM
Beside the measured number, compound 3's estimate is 1.3-fold (0.12 log units) above it, within the range that was stated.
By their numbers in this assay, from the lowest: compound 3; then compounds 1 and 2 (each within the scatter of the next).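

Placing 2-bromobenzyl on this oxygen gives the first change here that clearly moves the read-out in this assay (a 2.4-fold lower number from compound 1 to compound 3 (0.38 log units; beyond the scatter)). Unlike the halogen swap, this change goes beyond the scatter, towards higher toxicity in this test, although the step is modest. Nothing measured here explains the shift. On these data alone, it remains open whether the whole benzyl group or its bromine matters. A plain benzyl, a methyl or a longer chain carrying an amine on the same oxygen could help separate these possibilities.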